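Compound 3 and the limit of the assay

The source may report more compounds than this note shows. Statements on the series, on what has been measured and on what is new or still open speak of the compounds shown alone.

Measured in a functional assay on MDA-MB-231 cells (Homo sapiens) for antiproliferative activity, read by MTT assay, with a stated time of 48 h; a lower number here means a stronger inhibitor, a higher number a weaker inhibitor:
- compound 1 `CCN1C(=O)C(O)(Cc2nnn[nH]2)c2ccccc21`: > 100000 nM
- compound 2 `CN1C(=O)C(O)(Cc2nnn[nH]2)c2cc(Cl)ccc21`: > 100000 nM

In this assay compound 2 gives > 100000 nM, which is a limit of the assay and not a number. Compound 1 gives > 100000 nM, which is also a limit. Within the data shown here, neither compound has a measured number, and the series so far stands at one value: the limit of > 100000 nM in this assay, at which 2 of the 2 values shown sit.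

Compound 3 `CCN1C(=O)C(O)(Cc2nnn[nH]2)c2cc(Cl)ccc21` differs from compound 2 at a single place: methyl in place of hydrogen on a saturated chain carbon bound to an amide-type nitrogen in a ring. This is methyl in place of hydrogen on a saturated chain carbon bound to an amide-type nitrogen in a ring, which can also be read as methyl to ethyl. Among the measured compounds shown here, no measured step for this change is available. In this assay no shift beyond the scatter is expected, and a further limit is the likeliest report. This expectation rests on compound 2, whose value of > 100000 nM is a limit. The expected outcome is a number no higher from compound 2 to compound 3 (the limit leaves the size open). For compound 3 the estimated value is 100000 nM, with an expected range of 40000 nM to 250000 nM.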

Compound 3, half-maximal inhibitory concentration: 84900 nM
The estimate for compound 3 lay 1.2-fold (0.07 log units) above the measured number; measured number inside the range.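

In this assay, among these compounds, compound 3 gives 84900 nM, the only number among the values shown, so this combination of ethyl and chloro on the shared core brings the series just within reach of a reading. Methyl in place of hydrogen on a saturated chain carbon bound to an amide-type nitrogen in a ring gives an at least 1.1-fold lower number from compound 2 to compound 3 (0.07 log units; that floor lies within the scatter), and chloro in place of hydrogen on an aromatic carbon gives an at least 1.1-fold lower number from compound 1 to compound 3 (0.07 log units; that floor lies within the scatter), so neither change is shown to shift the number beyond the scatter. Both steps start from limits of the assay and not from numbers, which makes each of them a floor only, and most of the series still sits at that limit: the limit of > 100000 nM in this assay, at which 2 of the 3 values shown sit.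

Going by these compounds, the true size of each step stays open, and so does whether either change would count for anything without the other. Also open, on these data alone, is whether a longer chain such as propyl in place of the ethyl, or an amine or a carboxylic acid in place of the chloro, would give a lower number than compound 3 does.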